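This account rests on a few compounds, and the source may have more. Where it says the series, first, only, none or still open, it means among the compounds named here.

Series so far, in a functional assay on LoVo cells (Homo sapiens) for cytotoxicity, read by colorimetric assay and MTT assay; on this read-out lower numbers stand for stronger inhibition and higher numbers for weaker inhibition:
- compound 1 `COc1ccc2cc(-c3ccccc3)c(O)nc2c1`: 10000 nM
- compound 2 `COc1cc(OC)c2cc(-c3ccccc3)c(O)nc2c1`: 10000 nM
- compound 3 `CCOC(=O)Cn1c(=O)c(-c2ccc(OC)cc2)cc2c(OC)cc(OC)cc21`: 10000 nM

Compound 3 stands level with compound 1 and compound 2 at the digits shown. Next is compound 4 `COC(=O)CCn1c(=O)c(-c2ccc(OC)cc2)cc2c(OC)cc(OC)cc21`, which has the same atoms as compound 3, joined differently: (methoxycarbonyl)methyl in place of ethoxycarbonyl on a saturated chain carbon bound to an aromatic nitrogen. In words, (ethoxycarbonyl)methyl gives way to 2-(methoxycarbonyl)ethyl. Among the measured compounds shown here, the only measured step, no change at the digits printed from compound 1 to compound 2 (within the scatter), is methoxy in place of hydrogen on an aromatic carbon. It is a different change and stays within the scatter. For the measured compounds named here, no measured step touches this chain, so the evidence is indirect. No shift beyond the scatter is expected in this assay, in either direction. The expected step is no change at the digits printed from compound 3 to compound 4 (within the scatter). For compound 4 the estimated value is 10000 nM, with an expected range of 4000 nM to 15000 nM.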

Compound 4, half-maximal inhibitory concentration: 10000 nM
Beside the measured number, compound 4's estimate shows no gap at the digits printed; measured number inside the range.
By their numbers in this assay, from the lowest: compounds 1, 2, 3 and 4 (each within the scatter of the next).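

Moving from (ethoxycarbonyl)methyl to 2-(methoxycarbonyl)ethyl, with the same atoms joined differently, gives no change at the digits printed from compound 3 to compound 4 (within the scatter) in this assay. This chain on the aromatic nitrogen now has a direct reading, which the earlier methoxy step on an aromatic carbon could not give, and compound 4 stands at 10000 nM. No measurement at hand bears on why the number holds.

Going by these compounds, whether a free carboxylic acid, a primary amide or a longer chain ending in an amine would read differently at this place stays open.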